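This account rests on a few compounds, and the source may have more. Where it says the series, first, only, none or still open, it means among the compounds named here.

In a physicochemical assay for solubility, in phosphate buffer, at pH 7.4 (a lower number here means a less soluble compound, a higher number a more soluble compound), compound 1 `CC(=O)N[C@@H]1CCC[C@H](C(=O)Nc2cc(-c3cnc(C)n3C(C)C)ccn2)C1` gives 660000 nM and compound 2 `CC(=O)N[C@@H]1CCC[C@H](C(=O)Nc2cc(-c3cnn4c3CCCC4)ccn2)C1` gives 730000 nM. Compound 3 `CC(=O)N[C@@H]1CCC[C@H](C(=O)Nc2cc(-c3cnn4c3CCCC4)c(F)cn2)C1` gives > 1000000 nM, which is a limit of the assay and not a number, so its true position is not known.

The next structure, compound 4 `CC(=O)N[C@@H]1CCC[C@H](C(=O)Nc2cc(-c3cnn4c3CCCC4)c(Cl)cn2)C1`, keeps everything in compound 3 except one atom: chloro in place of fluoro on an aromatic carbon, (chloro in place of fluoro on an aromatic carbon).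

Going by the values given here, two measured steps bear on this change. The closer one puts fluoro in place of hydrogen on an aromatic carbon, and it is an at least 1.3-fold higher number from compound 2 to compound 3 (0.13 log units; that floor lies within the scatter). The other alters a different part of the molecule and is a 1.1-fold higher number from compound 1 to compound 2 (0.04 log units; within the scatter). Neither shows a change beyond the scatter, so no large move is expected here, in either direction.

The expected change is an at least 1.3-fold lower number from compound 3 to compound 4 (0.12 log units; that floor lies within the scatter). For compound 4 the estimate is 750000 nM, with an expected range of 400000 nM to 1000000 nM.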

Compound 4, solubility: 310000 nM
Compound 4: the middle estimate sits 2.4-fold (0.38 log units) above what was measured; the measured number lies below the stated range.
By their numbers in this assay, from the lowest: compound 4; then compounds 1 and 2 (each within the scatter of the next). At a limit, above all of these: compound 3.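

In this assay, this position, ortho to a group of 9 heavy atoms, now shows a step beyond the scatter: chloro in place of hydrogen gives a 2.4-fold lower number from compound 2 to compound 4 (0.37 log units; beyond the scatter). The earlier change here, fluoro in place of hydrogen, had shown only a floor within the scatter, so a clear move at this position is new, and it shows that the choice of atom matters. Chloro in place of fluoro gives an at least 3.2-fold lower number from compound 3 to compound 4 (0.50 log units; beyond the scatter), but this size is only a floor, since compound 3 stands at a limit of the assay: the limit of > 1000000 nM in this assay, at which 1 of the 4 values shown sits.

The compounds shown leave open how bromo, methyl or a nitrile would read at this position. They also leave open whether chloro would give a similar step alongside the group of 9 heavy atoms in compound 1.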